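Removing the whole side chain of compound 3

The source may hold more compounds than are shown below. What is called first, only, known or untested is meant among the compounds shown, and "the series" means these compounds.

Three hydroxamic acids built on the shared core of compound 1 `CCCC[C@H](NC(=O)OC(C)(C)C)C(=O)N[C@@H]1C[C@H](C(=O)NO)N(S(=O)(=O)c2ccc(OC)cc2)C1` have been measured in an assay on isolated protein for inhibition of matrix metalloproteinase-9 (Homo sapiens), read by fluorescence; on this read-out higher numbers stand for weaker inhibition and lower numbers for stronger inhibition. Compound 1 gives 131 nM. Compound 2 `COc1ccc(S(=O)(=O)N2C[C@H](NC(=O)CCCNC(=O)OC(C)(C)C)C[C@@H]2C(=O)NO)cc1` gives 49 nM, and compound 3 `COc1ccc(S(=O)(=O)N2C[C@H](NC(=O)CCCN)C[C@@H]2C(=O)NO)cc1` gives 53 nM. Compound 3 therefore stands second highest of the three numbers; its nearest neighbour is compound 2, a step of a 1.1-fold higher number from compound 2 to compound 3 (0.03 log units; within the scatter), and its furthest is compound 1, whose number is beyond the scatter above that of compound 3.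

Compound 4 `COc1ccc(S(=O)(=O)N2CCC[C@@H]2C(=O)NO)cc1` differs from compound 3 in one place: hydrogen in place of ((3-aminopropyl)carbonyl)amino on a saturated ring carbon. Going by the values given here, no measured step removes this chain altogether; the only measured step, that from compound 2 to compound 3, swaps one end of the chain and stays within the scatter. From the compounds shown here alone, compound 1 and compound 3 both carry a large group at that ring carbon, so the effect of bearing none is unknown. He expects a step of a 3.8-fold higher number from compound 3 to compound 4 (0.58 log units; beyond the scatter) toward weaker inhibition, and estimates compound 4 at 200 nM, with a range from 60 nM to 700 nM.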

Compound 4, half-maximal inhibitory concentration: 22 nM
Compound 4: middle estimate off by 9.1-fold (0.96 log units), on the high side; the whole stated range lies above it.
By their numbers in this assay, from the lowest: compound 4; then compounds 2 and 3 (each within the scatter of the next); then compound 1.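

Compound 4, with only hydrogen on this saturated ring carbon, shows that in this assay inhibition does not depend on a group at this position: removing ((3-aminopropyl)carbonyl)amino gives a 2.4-fold lower number from compound 3 to compound 4 (0.38 log units; beyond the scatter). The earlier step, a 1.1-fold higher number from compound 2 to compound 3 (0.03 log units; within the scatter), changed only one end of the chain, whereas removing the whole chain moves the number beyond the scatter, though modestly and toward stronger inhibition. Nothing measured here accounts for this gain on removing the chain.

The compounds shown leave open whether a much smaller group on this ring carbon, such as a lone amine or an acetamide, would give a number closer to that of compound 4 or that of compound 3. They also leave open how a chain ending in a carboxylic acid, or a longer chain, would compare.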